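The source may hold more compounds than are shown below. What is called first, only, known or untested is meant among the compounds shown, and "the series" means these compounds.

Values in an ADME assay on Vero cells (Chlorocebus sabaeus) for cytotoxicity, read by crystal violet staining; a higher number here means that more compound is tolerated, a lower number that less compound is tolerated:
- Compound 1 `c1ccc(/N=N/N2CCN(c3ccccc3)CC2)cc1`: >= 100000 nM, a limit of the assay
- Compound 2 `CN1CCN(/N=N/c2ccccc2)CC1`: 45000 nM
- Compound 3 `c1ccc(/N=N/N2CCN(c3ncccn3)CC2)cc1`: 65000 nM

The two actual numbers in the series lie close together: a 1.4-fold higher number from compound 2 to compound 3 (0.16 log units; within the scatter). Compound 1 is known only through its limit, as the limit of >= 100000 nM in this assay, at which 1 of the 3 values shown sits.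

The next structure is compound 4 `CCOC(=O)N1CCN(/N=N/c2ccccc2)CC1`, with ethoxycarbonyl in place of pyrimidin-2-yl on an amine nitrogen in a ring.

Three measured steps change this same place. The clearest is an at least 2.2-fold lower number from compound 1 to compound 2 (0.34 log units; beyond the scatter), although it starts from a limit and is only modest. The others are an at least 1.5-fold lower number from compound 1 to compound 3 (0.18 log units; that floor lies within the scatter) and a 1.4-fold higher number from compound 2 to compound 3 (0.16 log units; within the scatter). Since neither compound 2 nor compound 3 carries a phenyl there, the last step is the closest guide.

No change beyond the scatter is expected, with a 1.1-fold lower number from compound 3 to compound 4 (0.03 log units; within the scatter) as the expected step. For compound 4 the estimated value is 60000 nM, with an expected range of 28000 nM to 100000 nM.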

Compound 4, half-maximal cytotoxic concentration: 90000 nM
Compound 4: the middle estimate sits 1.5-fold (0.18 log units) below what was measured; the range from low to high includes it.
By their numbers in this assay, from the lowest: compounds 2, 3 and 4 (each within the scatter of the next). At a limit, above all of these: compound 1.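

In this assay, within the data shown here, ethoxycarbonyl is the first group on this amine nitrogen with a double bond outside aromatic rings, and neither step to it leaves the scatter: a 1.4-fold higher number from compound 3 to compound 4 (0.14 log units; within the scatter) and a 2.0-fold higher number from compound 2 to compound 4 (0.30 log units; within the scatter). Against phenyl, only a floor can be read: an at least 1.1-fold lower number from compound 1 to compound 4 (0.04 log units; that floor lies within the scatter). Among these compounds, the one step at this position that clears the scatter remains an at least 2.2-fold lower number from compound 1 to compound 2 (0.34 log units; beyond the scatter).

Going by these compounds, whether a carboxylic acid or a primary amine on a longer chain at this nitrogen would give a step beyond the scatter stays open. The true number for compound 1 also stays open: the limit of >= 100000 nM in this assay, at which 1 of the 4 values shown sits.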